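A Ring Closure Tested on a Chlorinated Stilbene

The compounds below may be only part of what the source reports. "The series", "measured", "known", "first", "only" and "open" are said of these compounds alone.

In a functional assay on HT-29 cells (Homo sapiens) for inhibition, read by sulforhodamine B assay, with a stated time of 48 h (on this read-out lower numbers stand for stronger inhibition and higher numbers for weaker inhibition), compound 1 `CCNC(=O)Nc1ccc(/C=C\c2cccc(Cl)c2)cc1` gives 26000 nM, compound 2 `CCNC(=O)Nc1ccc(/C=C\c2cc(C)cc(C)c2)cc1` gives 11000 nM, and compound 3 `Cc1cc(C)cc(/C=C\c2ccc(N3CCNC3=O)cc2)c1` gives 8.4 nM. The difference between the cores of compound 1 and compound 2 is not broken down here. Compound 3 arises from compound 2 by 2-oxoimidazolidin-1-yl in place of (ethylcarbamoyl)amino on an aromatic carbon, and in this assay that change gave a 1300-fold lower number from compound 2 to compound 3 (3.12 log units; beyond the scatter). Compound 4 `O=C1NCCN1c1ccc(/C=C\c2cccc(Cl)c2)cc1` arises from compound 1 by 2-oxoimidazolidin-1-yl in place of (ethylcarbamoyl)amino on an aromatic carbon. This is the same kind of change, though the surroundings differ: in compound 2 the place is para to a large group, in compound 1 it is para to a group of 9 heavy atoms. The expectation rests on compound 1 at 26000 nM together with the earlier step of a 1300-fold lower number from compound 2 to compound 3 (3.12 log units; beyond the scatter). On that basis a step of about a 1300-fold lower number from compound 1 to compound 4 (3.11 log units; beyond the scatter) is expected in this assay. Compound 4 is therefore estimated at 20 nM, with a likely range from 5 nM to 80 nM.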

Compound 4, half-maximal inhibitory concentration: 25 nM
Beside the measured number, compound 4's estimate is 1.3-fold (0.10 log units) below it; low and high end bracket the measured number.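

In this assay, putting 2-oxoimidazolidin-1-yl in place of (ethylcarbamoyl)amino gave a 1000-fold lower number from compound 1 to compound 4 (3.02 log units; beyond the scatter), so the large drop seen on the core of compound 2 appears again on the core of compound 1. The two steps agree: the same change on two cores in this assay, a 1300-fold lower number (3.12 log units; beyond the scatter) from compound 2 to compound 3 and a 1000-fold lower number (3.02 log units; beyond the scatter) from compound 1 to compound 4, 1.3-fold (0.10 log units) apart, within the scatter of two such steps. This shows that the change carried over between these two cores, but two cores are a small sample, and the numbers show neither why the ring form gives so much stronger inhibition nor that the step would hold on any further core.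

Left open is whether a longer chain, such as propyl in place of ethyl, would change the open-chain compounds. Also open, on these data alone, is whether a methoxy group in place of the chlorine of compound 4 would keep its value.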